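The source may report more compounds than this note shows. Statements on the series, on what has been measured and on what is new or still open speak of the compounds shown alone.

Of the compounds shown here, three have been measured. Compound 1 `COc1ccc(CNC(=O)c2nc(C(C)(C)NC(=O)OCc3ccccc3)nc(O)c2O)cc1` gives 164000 nM in an ADME assay on C8166 cells (Homo sapiens) for cytotoxicity, read by MTT assay, with a stated time of 3 days; on this read-out lower numbers stand for higher toxicity in this test and higher numbers for lower toxicity in this test. Compound 2 `CC(C)(NC(=O)OCc1ccccc1)c1nc(O)c(O)c(NC(=O)NCc2ccc(F)cc2)n1` gives 81100 nM. Compound 3 `COc1ccc(CNC(=O)Nc2nc(C(C)(C)NC(=O)OCc3ccccc3)nc(O)c2O)cc1` reaches only the limit > 500000 nM, which is a limit of the assay and not a number (the limit of > 500000 nM in this assay, at which 1 of the 3 values shown sits).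

Among the measured compounds shown here, compound 1 holds the highest of the two numbers; compound 2 sits an at least 6.1-fold higher number from compound 2 to compound 3 (0.78 log units; beyond the scatter) below the limit of compound 3, the one measured step, which changes an aromatic substituent. Compound 4 `COCCCNC(=O)c1nc(C(C)(C)NC(=O)OCc2ccccc2)nc(O)c1O` differs from compound 1 by 2-methoxyethyl in place of 4-methoxyphenyl on a saturated chain carbon bound to an amide-type nitrogen. For the measured compounds named here, no measured step bears on that change, so no shift beyond the scatter is expected. Compound 4 is therefore expected to give 200000 nM, between 80000 nM and 500000 nM. The expected step is a 1.2-fold higher number from compound 1 to compound 4 (0.09 log units; within the scatter).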

Compound 4, half-maximal cytotoxic concentration: 259000 nM
The estimate for compound 4 lay 1.3-fold (0.11 log units) below the measured number, within the range that was stated.
By their numbers in this assay, from the lowest: compound 2; then compounds 1 and 4 (each within the scatter of the next). At a limit, above all of these: compound 3.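

In this assay, replacing 4-methoxyphenyl with 2-methoxyethyl on a saturated chain carbon bound to an amide-type nitrogen gives a step that stays within the scatter (a 1.6-fold higher number from compound 1 to compound 4 (0.20 log units; within the scatter)). Among the compounds shown here, the one earlier step changed only a substituent on an aromatic ring, whereas this change removes the ring from this position, and the read-out does not move beyond the scatter. Nothing available gives a cause for this result.

As far as these compounds go, it remains open whether an amine or a carboxylic acid on this chain would leave the read-out within the scatter. From the compounds shown here alone, it is equally open whether a plain butyl chain would do so.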